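Replacing a Dimethoxyphenyl Ester with a Chlorophenylethenyl Ester

The source may report more compounds than this note shows. Statements on the series, on what has been measured and on what is new or still open speak of the compounds shown alone.

Compound 2 `COc1cc(C2Oc3cc([C@H]4Oc5cc(O)cc(O)c5C(=O)[C@@H]4O)ccc3OC2COC(=O)c2ccc(OC)c(OC)c2)ccc1O` gives 16000 nM in a functional assay on liver (Rattus norvegicus, strain Sprague-Dawley) for inhibition, with a stated time of 1 h; on this read-out lower numbers stand for stronger inhibition and higher numbers for weaker inhibition. Among the three measured compounds it stands second highest: compound 1 `COc1cc(C2Oc3cc([C@H]4Oc5cc(O)cc(O)c5C(=O)[C@@H]4O)ccc3OC2COC(=O)c2cc(OC)c(OC)c(OC)c2)ccc1O` gives 25700 nM and differs by a 1.6-fold lower number from compound 1 to compound 2 (0.21 log units; within the scatter), while compound 3 `COc1cc(C2Oc3cc([C@H]4Oc5cc(O)cc(O)c5C(=O)[C@@H]4O)ccc3OC2COC(=O)c2cc(N)cc([N+](=O)[O-])c2)ccc1O` gives 200 nM, reached by an 80-fold lower number from compound 2 to compound 3 (1.90 log units; beyond the scatter). Compound 4 `COc1cc(C2Oc3cc([C@H]4Oc5cc(O)cc(O)c5C(=O)[C@@H]4O)ccc3OC2COC(=O)/C=C/c2ccc(Cl)cc2)ccc1O` carries 2-(4-chlorophenyl)ethenyl in place of 3,4-dimethoxyphenyl on a carbonyl carbon. Among the compounds with values here, no measured step introduces a 2-(4-chlorophenyl)ethenyl group; the step from compound 1 to compound 2 stays within the scatter, whereas the step from compound 2 to compound 3 shows that another group on the carbonyl carbon can lower the number sharply. Compound 4 is therefore expected to show a 2.0-fold lower number from compound 2 to compound 4 (0.30 log units; within the scatter), with wide uncertainty. The estimated value of compound 4 is 8000 nM, between 1500 nM and 40000 nM.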

Compound 4, half-maximal inhibitory concentration: 12000 nM
For compound 4 the middle estimate is 1.5-fold (0.18 log units) below the measured one, and the stated range covers the measured number.
By their numbers in this assay, from the lowest: compound 3; then compounds 4, 2 and 1 (each within the scatter of the next, the first and the last beyond it).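

In this assay, the group on the carbonyl carbon can change from an aromatic ring to 2-(4-chlorophenyl)ethenyl, which has 0 hydrogen-bond acceptors, with no shift beyond the scatter (a 1.3-fold lower number from compound 2 to compound 4 (0.12 log units; within the scatter)). The new group stands only modestly apart from 3,4,5-trimethoxyphenyl (a 2.1-fold lower number from compound 1 to compound 4 (0.33 log units; beyond the scatter)) but far from 3-amino-5-nitrophenyl (a 60-fold higher number from compound 3 to compound 4 (1.78 log units; beyond the scatter)), so among these four groups only 3-amino-5-nitrophenyl gives a large drop. On these data alone, whether the double bond or the chlorine matters remains open, and a 2-(4-chlorophenyl)ethyl or an unsubstituted 2-phenylethenyl group would separate them. Nothing measured here explains the large gap to compound 3.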